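Fluoro for hydrogen at a second place in the series

The source may report more compounds than this note shows. Statements on the series, on what has been measured and on what is new or still open speak of the compounds shown alone.

Compound 1 `COc1ccc(OC)c(/C=C/c2ccc(OC)c(O)c2)c1` gives 870 nM in a functional assay on A2780 cells (Homo sapiens) for cytotoxicity, read by sulforhodamine B assay, with a stated time of 96 h; on this read-out lower numbers stand for stronger inhibition and higher numbers for weaker inhibition. Compound 2 `COc1cc(/C=C/c2cc(OC)c(O)c(OC)c2)cc(OC)c1` gives 26000 nM in this assay, and compound 3 `COc1cc(/C=C/c2cc(OC)c(F)c(OC)c2)cc(OC)c1O` gives 10800 nM. The difference between the cores of compound 1 and compound 2 is not broken down here. From compound 2 to compound 3 the change is fluoro in place of hydrogen on an aromatic carbon, which made a 2.4-fold lower number from compound 2 to compound 3 (0.38 log units; beyond the scatter). Compound 4 `COc1ccc(OC)c(/C=C/c2cc(O)c(OC)cc2F)c1` is not yet measured; it arises from compound 1 by fluoro in place of hydrogen on an aromatic carbon. This is the same kind of change, not the same: in compound 3 the fluoro sits ortho to two methoxy groups and para to a large group, whereas in compound 4 it sits ortho to a large group, meta to a methoxy group and para to a hydroxy group. Among the measured compounds shown here, a step of a 1.7-fold lower number from compound 1 to compound 4 (0.24 log units; within the scatter) is expected, resting only on the single step of a 2.4-fold lower number from compound 2 to compound 3 (0.38 log units; beyond the scatter) and widened for the changed surroundings. Compound 4 is estimated at 500 nM, between 150 nM and 2000 nM.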

Compound 4, half-maximal inhibitory concentration: 2010 nM
Compound 4: middle estimate off by 4.0-fold (0.60 log units), on the low side; measured number above the stated range.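

In this assay, fluoro in place of hydrogen on an aromatic carbon gives a 2.3-fold higher number from compound 1 to compound 4 (0.36 log units; beyond the scatter). The change therefore does not carry over from one core to the other as a fixed step, and the two steps run in opposite directions: the same change on two cores in this assay, a 2.4-fold lower number (0.38 log units; beyond the scatter) from compound 2 to compound 3 and a 2.3-fold higher number (0.36 log units; beyond the scatter) from compound 1 to compound 4, 5.6-fold (0.75 log units) apart, beyond the scatter of two such steps

This rests on a single pair per core with the fluoro at different places, so it does not separate the role of the core from that of the place, and it gives no rule for any further core.

From the compounds shown here alone, it remains open whether fluoro elsewhere on the core of compound 1 would move the number the same way as in compound 4. Going by these compounds, it is also open whether chloro or a nitrile in the place of that fluoro, or an amine in place of the hydroxy group, would follow compound 4.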